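The compounds below may be only part of what the source reports. "The series", "measured", "known", "first", "only" and "open" are said of these compounds alone.

Compound 1 `C/C(=C\CC/C(C)=C/CC[C@@H]1[C@@]2(C)CCC(=O)C(C)(C)[C@H]2CC[C@@]1(C)O)CC/C=C(\C)C(=O)OCc1cn(-c2ccc([N+](=O)[O-])cc2)nn1` gives > 150000 nM in a functional assay on DU-145 cells (Homo sapiens) for antiproliferative activity, read by MTT assay, with a stated time of 48 h (a higher number here means a weaker inhibitor, a lower number a stronger inhibitor), which is a limit of the assay rather than a number.
Compound 2 `C/C(=C\CC/C(C)=C/CC[C@@H]1[C@@]2(C)CCC(=O)C(C)(C)[C@H]2CC[C@@]1(C)O)CC/C=C(\C)C(=O)OCc1cn(-c2cccc([N+](=O)[O-])c2)nn1` gives > 150000 nM in this assay, again a limit.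
Compound 3 `C/C(=C\CC/C(C)=C/CC[C@@H]1[C@@]2(C)CCC(=O)C(C)(C)[C@H]2CC[C@@]1(C)O)CC/C=C(\C)C(=O)OCc1cn(-c2cccc(C)c2)nn1` gives 137000 nM in this assay.

Compound 1 therefore stands at the limit of > 150000 nM in this assay, at which 2 of the 3 values shown sit, and only a limit is known for it. The measured steps say little: a step that the two limits leave unreadable from compound 1 to compound 2, while an at least 1.0-fold lower number from compound 1 to compound 3 (0.03 log units; that floor lies within the scatter) and an at least 1.0-fold lower number from compound 2 to compound 3 (0.03 log units; that floor lies within the scatter) set floors that lie within the scatter. All three substituents on the aromatic nitrogen of the shared core leave the compounds weak in this assay.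

Compound 4 `C/C(=C\CC/C(C)=C/CC[C@@H]1[C@@]2(C)CCC(=O)C(C)(C)[C@H]2CC[C@@]1(C)O)CC/C=C(\C)C(=O)OCc1cn(-c2cccc(C(F)(F)F)c2)nn1` carries the change (3-(trifluoromethyl)phenyl in place of 4-nitrophenyl on an aromatic nitrogen). For the measured compounds named here, no measured step covers the trifluoromethyl group, so the expectation rests only on the three compounds sitting at or close to the limit. The step of a number no higher from compound 1 to compound 4 (the limit leaves the size open) is expected to be unreadable against the limit of compound 1, with compound 4 likely at or near the same limit. Compound 4 is estimated at 150000 nM, within a range of 80000 nM to 300000 nM.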

Compound 4, half-maximal inhibitory concentration: > 150000 nM
Compound 4: only a limit was reported; the forecaster's own chance of this, stated with the estimate: 55%; the middle value sits exactly at the limit.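

The 3-(trifluoromethyl)phenyl group joins the other substituents on the aromatic nitrogen in leaving the shared core weak in this assay, and the result for compound 4 is a limit of the assay, not a number: the limit of > 150000 nM in this assay, at which 3 of the 4 values shown sit.

The steps to compound 4 from compound 1 and from compound 2 cannot be read, as both ends of each are limits. Replacing the methyl group on the aromatic carbon with a trifluoromethyl group gives an at least 1.0-fold higher number from compound 3 to compound 4 (0.03 log units; that floor lies within the scatter), so this pair shows no difference beyond the scatter and leaves the true size open.

From the compounds shown here alone, it remains open whether an amine or a carboxylic acid on the phenyl ring, or a longer chain in place of that ring, would bring a clearly lower number in this assay. Going by these compounds, all four compounds share one core, so the effect of any change to that core is also open.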